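Ring-Nitrogen Substituent Swap on a Shared Triazine Core

A few compounds are considered here, and "the series" means these few. Any claim that something is new, unique, unknown or untested is made for them only; others in the source may bear on it.

Compound 1 `N#Cc1ccc(Nc2nc(Oc3ccnc4ccccc34)nc(N3CCN(c4ccc(F)cc4)CC3)n2)cc1C(F)(F)F`: > 100000 nM, a limit of the assay
Compound 2 `CN1CCN(c2nc(Nc3ccc(C#N)c(C(F)(F)F)c3)nc(Oc3ccnc4ccccc34)n2)CC1`: > 100000 nM, a limit of the assay
Compound 3 `N#Cc1ccc(Nc2nc(Oc3ccnc4ccccc34)nc(N3CCN(c4ccccn4)CC3)n2)cc1C(F)(F)F`: > 100000 nM, a limit of the assay

All three compounds were tested in a functional assay on DU-145 cells (Homo sapiens) for cytotoxicity, read by sulforhodamine B assay, with a stated time of 48 h; on this read-out lower numbers stand for higher toxicity in this test and higher numbers for lower toxicity in this test. Compound 3 stands at a limit of the assay, not at a number. Compound 1 also gives only a limit in this assay. Compound 2 likewise gives only a limit in this assay. The shared picture is the limit of > 100000 nM in this assay, at which 3 of the 3 values shown sit, so none of the three compounds shows measurable toxicity within the tested range.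

The steps between the measured compounds therefore cannot be read: from compound 1 to compound 2 the step is a step that the two limits leave unreadable from compound 1 to compound 2, from compound 1 to compound 3 it is a step that the two limits leave unreadable from compound 1 to compound 3, and from compound 2 to compound 3 it is a step that the two limits leave unreadable from compound 2 to compound 3. Changing the group on the ring nitrogen has so far never moved a compound off the limit.

Compound 4 `N#Cc1ccc(Nc2nc(Oc3ccnc4ccccc34)nc(N3CCN(c4cccc(Cl)c4Cl)CC3)n2)cc1C(F)(F)F` differs from compound 3 in one place: 2,3-dichlorophenyl in place of pyridin-2-yl on an amine nitrogen in a ring. Going by the values given here, the three unreadable steps are the only evidence bearing on this change, and they all sit at the limit. The expectation for compound 4 is therefore another limit, with an estimated step from compound 3 to compound 4 of a number no higher from compound 3 to compound 4 (the limit leaves the size open). Compound 4 is estimated at 100000 nM, with an expected range from 30000 nM to 300000 nM.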

Compound 4, concentration lethal to 50% of the cells: > 100000 nM
Compound 4 was reported as a limit (the forecaster's own chance of this, stated with the estimate: 80%); the middle value lies on the limit itself.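

Compound 4 also gives only a limit in this assay, so its steps from compound 1, compound 2 and compound 3 cannot be read. All four compounds share the same result: the limit of > 100000 nM in this assay, at which 4 of the 4 values shown sit.

The compounds shown leave open whether any group on this ring nitrogen can bring a measurable value in this assay, and whether these four compounds differ from one another at all.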